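The source may report more compounds than this note shows. Statements on the series, on what has been measured and on what is new or still open speak of the compounds shown alone.

Compound 1 `CCCCCC(=O)Nc1ncc(C(Oc2ccc3cc(Br)ccc3c2)c2ccc(Cl)cc2)s1` and compound 2 `Cc1noc(C)c1C(=O)Nc1ncc(C(Oc2ccc3cc(Br)ccc3c2)c2ccc(Cl)cc2)s1` share one core and differ only in the acyl group on the amide nitrogen. In an ADME assay on HepG2 2.2.15 cells (Homo sapiens) for cytotoxicity (on this read-out higher numbers stand for lower toxicity in this test and lower numbers for higher toxicity in this test), compound 1 gives > 50000 nM; this is a limit of the measurement, not a number. Compound 2 is reported in this assay as "not toxic" (no number reported), again without a number, so its standing can be described only as sitting with compound 1 at the limit of > 50000 nM in this assay, at which 1 of the 2 values shown sits. Compound 3 `O=C(Nc1ncc(C(Oc2ccc3cc(Br)ccc3c2)c2ccc(Cl)cc2)s1)c1ccc(Cl)nc1` carries 6-chloropyridin-3-yl in place of 3,5-dimethyl-1,2-oxazol-4-yl on a carbonyl carbon. For the measured compounds named here, no measured step between the two acyl variants exists, so the expected step in this assay is none beyond the scatter, in either direction, as neither compound 1 nor compound 2 reached a numerical value. Compound 3 is therefore expected to give in this assay a half-maximal cytotoxic concentration near 50000 nM, within 20000 nM to 100000 nM, most probably reported again only as a limit.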

Compound 3, half-maximal cytotoxic concentration: "not toxic" (no number reported)
Nothing numeric was reported for compound 3; no gap can be computed for the estimate.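

Compound 2 and compound 3 are both reported as "not toxic", without a number, in this assay, so no step can be read between them. The compounds shown leave open whether changing the acyl group on the amide nitrogen shifts the half-maximal cytotoxic concentration in this assay at all.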